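The compounds below may be only part of what the source reports. "The series", "measured", "known", "first", "only" and "open" are said of these compounds alone.

Measured compounds:
Compound 1 `CN(C)CCCOc1ccc(CN(C)c2nc3ccc(Oc4ccc(C(F)(F)F)cc4)cc3s2)cc1` gives 46000 nM in an assay on SH-SY5Y cells for inhibition of Voltage-dependent N-type calcium channel subunit alpha-1B (Homo sapiens), read by FLIPR and calcium flux, with stated times of 600 s and 300 s, in the presence of a further agent that is not named here; on this read-out lower numbers stand for stronger inhibition and higher numbers for weaker inhibition.
Compound 2 `NCCCOc1ccc(CNc2nc3ccc(Oc4ccc(C(F)(F)F)cc4)cc3s2)cc1` gives 59000 nM in this assay.
Compound 3 `CN(Cc1ccc(OCCCN)cc1)c1nc2ccc(Oc3ccc(C(F)(F)F)cc3)cc2s1` gives 283000 nM in this assay.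

Compound 3 stands highest of the three numbers in this assay, that is, it is the weakest inhibitor of the set. Both steps that lead to it raise the number: a 6.2-fold higher number from compound 1 to compound 3 (0.79 log units; beyond the scatter) and a 4.8-fold higher number from compound 2 to compound 3 (0.68 log units; beyond the scatter). Each of these concerns the amine end of the molecule, either the chain amine or the ring nitrogen.

Compound 4 `CN(Cc1ccc(OCCCN)cc1)c1nc2ccc(Oc3ccc(O)cc3)cc2s1` differs from compound 3 at one place only: hydroxy in place of trifluoromethyl on an aromatic carbon. Going by the values given here, none of the measured steps touches this position, and all three measured compounds carry the same trifluoromethyl group, so no measured pair anchors the direction or size of this step in this assay. Only a wide estimate is possible. Compound 3 already sits at a very high number, so any further rise would run close to the edge of what the assay resolves, and a limit rather than a number is a real possibility. Compound 4 is expected at about 400000 nM, within 100000 nM to 1500000 nM. The step from compound 3 implied by this estimate, a 1.4-fold higher number from compound 3 to compound 4 (0.15 log units; within the scatter), is expected to be modest and uncertain in direction.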

Compound 4, half-maximal inhibitory concentration: 117000 nM
Estimate against measurement, compound 4: 3.4-fold (0.53 log units) above; the measured number falls inside the stated range.
By their numbers in this assay, from the lowest: compounds 1, 2 and 4 (each within the scatter of the next, the first and the last beyond it); then compound 3.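

In this assay, going by these compounds alone, a 2.4-fold lower number from compound 3 to compound 4 (0.38 log units; beyond the scatter) is the first step at the far aromatic ring, and it shows that the group on this aromatic carbon affects the number, not only the chain amine and the nitrogen on the aromatic ring. Trifluoromethyl is therefore not needed here for inhibition at this level, since hydroxy, with fewer heavy atoms and with a hydrogen-bond donor and acceptor, gives a lower number in this one background, which has the primary amine on the chain and the methyl on the ring nitrogen. Nothing available accounts for the direction or size of this step.

The compounds shown leave open whether the same replacement lowers the number when the chain ends in dimethylamino, as in compound 1, or when the ring nitrogen carries hydrogen, as in compound 2. They also cannot separate the loss of trifluoromethyl from the arrival of hydroxy, a question that plain hydrogen, methoxy or a carboxylic acid on the same aromatic carbon would help to settle.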